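A few compounds are considered here, and "the series" means these few. Any claim that something is new, unique, unknown or untested is made for them only; others in the source may bear on it.

Compound 1 (`Brc1cccc2cc3c(nc12)-c1nc2ccccc2n1C3`): 66000 nM
Compound 2 (`Cc1cccc2cc3c(nc12)-c1nc2ccccc2n1C3`): > 100000 nM

In a functional assay on HT-1080 cells (Homo sapiens) for cytotoxicity, read by MTT assay, with a stated time of 72 h (a higher number here means a weaker inhibitor, a lower number a stronger inhibitor), compound 1 gives 66000 nM as a measured number. Compound 2 reads > 100000 nM as a limit of the assay and not a number. Compound 3 (`COc1cccc2cc3c(nc12)-c1nc2ccccc2n1C3`) carries methoxy in place of methyl on an aromatic carbon. Within the data shown here, the only measured step that bears on this is an at least 1.5-fold higher number from compound 1 to compound 2 (0.18 log units; that floor lies within the scatter) and it involves bromo and methyl rather than methoxy, so it offers weak guidance and no step beyond the scatter is expected. In this assay the estimated change is an at least 1.1-fold lower number from compound 2 to compound 3 (0.04 log units; that floor lies within the scatter) and no clear direction is expected. Compound 3 is estimated at 90000 nM with 35000 nM to 200000 nM as its expected range.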

Compound 3, half-maximal inhibitory concentration: > 100000 nM
Compound 3 gave a limit, no number; the forecaster's own chance of this, stated with the estimate: 55%; at least 1.1-fold (0.04 log units) between middle value and limit.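

With methoxy on this aromatic carbon, the shared core again gives no measured number in this assay, so a second group joins methyl at the limit of the assay. Replacing bromo with methoxy gives an at least 1.5-fold higher number from compound 1 to compound 3 (0.18 log units; that floor lies within the scatter), so bromo is not shown to differ from methoxy. The steps involving only limits cannot be read, and the values now gather at a single ceiling: the limit of > 100000 nM in this assay, at which 2 of the 3 values shown sit.

Still open, going by these compounds, is whether an amine or a carboxylic acid on this aromatic carbon would give a measured number.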